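The Step From Compound 3 to Compound 4

The source may report more compounds than this note shows. Statements on the series, on what has been measured and on what is new or still open speak of the compounds shown alone.

In an ADME assay (liver) for metabolic stability, with Liver microsome (Rattus norvegicus) as the target, read by LC-MS, using microsomes and NADPH, with stated times of 5 min and 60 min, tested at 4 uM (on this read-out lower numbers stand for a less stable compound and higher numbers for a more stable compound), compound 3 (`Cc1c(OCCCCOc2ccc(C(=O)O)cc2Cl)ccc(C(=O)CC(C)C)c1O`) gives 61%, within the scatter of compound 1 (`Cc1c(OCCCCOc2ccc(C(=O)O)cc2F)ccc(C(=O)CC(C)C)c1O`) at 57% and of compound 2 (`Cc1c(OCCCCOc2cccc(C(=O)O)c2)ccc(C(=O)CC2CCCC2)c1O`) at 55%. Compound 4 (`Cc1c(OCCCCOc2cccc(C(=O)O)c2)ccc(C(=O)CC(C)C)c1O`) differs from compound 3 in one place, 3-carboxyphenyl in place of 4-carboxy-2-chlorophenyl on an oxygen on a saturated carbon. Going by the values given here, the only measured single-place step, a number 4 percentage points higher from compound 1 to compound 3 (within the scatter), exchanges fluoro for chloro on an aromatic carbon. Compound 2 carries the same 3-carboxyphenyl group but differs from compound 4 elsewhere, and its value lies within the scatter of the others. No step beyond the scatter is therefore expected, and the estimated change is a number 4 percentage points lower from compound 3 to compound 4 (within the scatter). Compound 4 is expected at 57%, within an estimated range of 46% to 68%.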

Compound 4, percent of the compound remaining: 51%
Beside the measured number, compound 4's estimate is 6 percentage points above it; the measured number falls inside the stated range.
By their numbers in this assay, from the lowest: compounds 4, 2, 1 and 3 (each within the scatter of the next).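

In this assay, replacing the halogen-bearing aryl groups with 3-carboxyphenyl on an oxygen on a saturated carbon stays within the scatter, with a number 10 percentage points lower from compound 3 to compound 4 (within the scatter) and a number 6 percentage points lower from compound 1 to compound 4 (within the scatter). Isopropyl in place of cyclopentyl on a saturated chain carbon bound to a carbonyl carbon also stays within it, with a number 4 percentage points lower from compound 2 to compound 4 (within the scatter). So none of the changes at either place yet separates these compounds on this read-out.

No evidence bears on why these numbers fall as they do. Going by these compounds, whether an amide in place of the carboxylic acid, or a longer chain on that oxygen, would move the number beyond the scatter remains open.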